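This account rests on a few compounds, and the source may have more. Where it says the series, first, only, none or still open, it means among the compounds named here.

Two compounds of the series have readings so far. In an ADME assay on microsomes from liver (Rattus norvegicus) for metabolic stability, with a stated time of 10 min, tested at 1 uM (a higher number here means that more of the compound is left, a lower number that less of the compound is left), compound 1 `COc1c(-c2ccc(C(F)(F)F)cc2Cl)ccc2c1cnn2[C@@H](CC(C)C)c1ccc(C(=O)NCCC(=O)O)cc1` gives 97%, and compound 2 `COc1c(-c2ccc(C(F)(F)F)cc2Cl)ccc2nn([C@@H](CC(C)C)c3ccc(C(=O)NCCC(=O)O)cc3)cc12` gives 84%. Compound 2 therefore holds the lower of the two numbers, and its gap to compound 1 lies beyond the scatter.

The next compound to be read is compound 3 `COc1c(-c2ccc(C(F)(F)F)cc2Cl)ccc2nn([C@H](CC(C)C)c3ccc(C(=O)NCCC(=O)O)cc3)cc12`. Its relation to compound 2 is simple: the two compounds have the same atoms and bonds and differ only in configuration as drawn: 1 of 1 stereo elements differ; a stereocentre at a saturated chain carbon is drawn S in compound 2 and R in compound 3. Nothing leaves and nothing enters; a stereocentre at a saturated chain carbon is drawn S in compound 2 and R in compound 3.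

Among the compounds with values here, no measured pair differs only in configuration, so the data give no direct size for such a step. Within the data shown here, the only anchor is compound 2 at 84%, and a reading near that number is expected, with a wide margin for the missing precedent. The expected step, a number 1 percentage points lower from compound 2 to compound 3 (within the scatter), is estimated to stay within the scatter, with no direction favoured. For compound 3 the estimated value is 83%, with an expected range from 66% to 95%.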

Compound 3, percent of the compound remaining: 100%
Compound 3: middle estimate off by 17 percentage points, on the low side; measured number outside the range, above it.
By their numbers in this assay, from the lowest: compound 2; then compounds 1 and 3 (each within the scatter of the next).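

In this assay, within the data shown here, the configuration at the saturated chain carbon is the first single change with a measured size, the switch from S to R giving a number 16 percentage points higher from compound 2 to compound 3 (beyond the scatter). The pair shows that this stereocentre is not a silent position for the read-out, with the R form leaving more compound than the S form in this one comparison. No atom or bond changes, so the step can only be assigned to the stereocentre, for this reason: the fact that compounds 2 and 3 differ only in the configuration as drawn

With compound 3 at 100%, this one pair gives only a single measured size for how far configuration can move the number. As far as these compounds go, it remains open whether the same preference for R holds on the core of compound 1, or when a longer chain replaces the chain at the stereocentre or an amine replaces the carboxylic acid.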